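Adding a second chlorine to the weakest of two carbamates

The compounds below may be only part of what the source reports. "The series", "measured", "known", "first", "only" and "open" are said of these compounds alone.

Within the data shown here, compound 2 `Cc1c(C(C)OC(=O)Nc2ccc(Cl)cc2)oc2ncnn12` gives 2510 nM in a functional assay on CHO cells for antagonist activity at metabotropic glutamate receptor 5 (Homo sapiens), read by calcium flux (a lower number here means a stronger inhibitor, a higher number a weaker inhibitor), the highest of the two numbers recorded; its only neighbour, compound 1 `Cc1c(C(C)OC(=O)Nc2cccc(Cl)c2)oc2ncnn12`, gives 39.8 nM. Among the measured compounds shown here, the one recorded step, a 63-fold higher number from compound 1 to compound 2 (1.80 log units; beyond the scatter), was large and beyond the scatter. Compound 3 `Cc1c(C(C)OC(=O)Nc2ccc(Cl)c(Cl)c2)oc2ncnn12` differs from compound 2 by chloro in place of hydrogen on an aromatic carbon, so it carries both chlorines seen singly in compounds 1 and 2. Because compound 1 with its 3-chlorophenyl gave 39.8 nM, a lower number than compound 2 is expected, though the step is estimated to be smaller than the recorded one: a 17-fold lower number from compound 2 to compound 3 (1.22 log units; beyond the scatter). Compound 3 is expected at 150 nM, within 30 nM to 800 nM.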

Compound 3, half-maximal inhibitory concentration: 5010 nM
Estimate against measurement, compound 3: 33-fold (1.52 log units) below; the whole stated range lies below it.
By their numbers in this assay, from the lowest: compound 1; then compounds 2 and 3 (each within the scatter of the next).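

Adding chloro gives a 2.0-fold higher number from compound 2 to compound 3 (0.30 log units; within the scatter) in this assay so the two cannot be told apart. The chlorine that goes with the strong result of compound 1 brings no such result here, while adding chloro gives a 130-fold higher number from compound 1 to compound 3 (2.10 log units; beyond the scatter) and that step is large. The effect of a chloro group on this ring therefore depends on the chlorine already present, at least in these compounds, and nothing available explains why. Going by these compounds, it remains open whether a smaller fluoro or a methyl group at that place on compound 1 would also weaken it so strongly.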